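A few compounds are considered here, and "the series" means these few. Any claim that something is new, unique, unknown or untested is made for them only; others in the source may bear on it.

Working notes on the series. In an assay on CHO-K1 cells for displacement of a labelled ligand from prostaglandin E2 receptor EP1 subtype (Homo sapiens) (a lower number here means a stronger inhibitor, a higher number a weaker inhibitor), compound 1 `O=C(O)c1ccn(Cc2cc(Br)ccc2OCc2ccccc2)n1` gives 9.77 nM. Compound 2 `O=C(O)c1nn(Cc2cc(Br)ccc2OCc2ccccc2)cc1F` gives 123 nM in this assay. The change between them is fluoro in place of hydrogen on an aromatic carbon and it produced a 13-fold higher number from compound 1 to compound 2 (1.10 log units; beyond the scatter). Compound 3 `Cc1cc(C(=O)O)nn1Cc1ccccc1OCc1ccc(Cl)cc1Cl` belongs to a different core; the difference between the two cores is not broken down here. For compound 3 this assay reports only a limit, < 2000 nM, consistent with the limit of < 2000 nM in this assay, at which 1 of the 3 values shown sits. Compound 4 `Cc1cc(C(=O)O)nn1Cc1cc(F)ccc1OCc1ccc(Cl)cc1Cl` is not yet measured. It differs from compound 3 by fluoro in place of hydrogen on an aromatic carbon. For the measured compounds named here, this is the same kind of change as the one from compound 1 to compound 2, not the same: in compound 2 the fluoro sits on a five-membered aromatic ring with 2 nitrogen, next to the ring atom that bears a carboxy group, whereas in compound 4 it sits on a six-membered aromatic ring of carbon only, meta to a large group and para to a large group. With compound 3 known only as a limit, the step that the limit leaves unreadable from compound 3 to compound 4 is expected to be small, and compound 4 is estimated at 1500 nM, plausibly between 300 nM and 6000 nM.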

Compound 4, half-maximal inhibitory concentration: 355 nM
Compound 4: the middle estimate sits 4.2-fold (0.63 log units) above what was measured; measured number inside the range.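

The step from compound 3 to compound 4 cannot be read, since the value for compound 3 is only a limit: the limit of < 2000 nM in this assay, at which 1 of the 4 values shown sits. The compounds shown leave open whether, and in which direction, fluoro in place of hydrogen on the six-membered aromatic ring of carbon only changes the number for compound 3.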